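Cytotoxicity tolerance across the shared core: compound 1 to compound 3

The compounds below may be only part of what the source reports. "The series", "measured", "known", "first", "only" and "open" are said of these compounds alone.

Compound 1 `COc1ccccc1CNC(=O)CSc1cn(C)c2ccccc12` is the starting point of the series. In an ADME assay on HEK-293T cells (Homo sapiens) for cytotoxicity, read by CCK-8 assay, with a stated time of 24 h (a lower number here means that less compound is tolerated, a higher number that more compound is tolerated), compound 1 gives > 100000 nM, which is a limit of the assay rather than a number. Compound 2 `O=C(CSc1c[nH]c2ccccc12)N(Cc1ccccc1)Cc1ccccc1` in this assay gives > 100000 nM, likewise a limit. Compound 1 thus stands at the limit of > 100000 nM in this assay, at which 2 of the 2 values shown sit. Compound 3 `Cn1cc(SCC(=O)NCc2ccc(Cl)c(Cl)c2)c2ccccc21` carries 3,4-dichlorophenyl in place of 2-methoxyphenyl on a saturated chain carbon bound to an amide-type nitrogen. Among the compounds with values here, no step between measured compounds is known here; the expected step from compound 1 to compound 3 is a number no higher from compound 1 to compound 3 (the limit leaves the size open), none beyond the scatter. Compound 3 is estimated at 100000 nM in this assay, with a range from 40000 nM to 300000 nM, and most likely again reported only as a limit.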

Compound 3, half-maximal cytotoxic concentration: > 100000 nM
Compound 3 ended at the assay's limit; the forecaster's own chance of this, stated with the estimate: 70%; the middle value sits exactly at the limit.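

In this assay compound 3 gives > 100000 nM, a limit of the assay. Within the data shown here, compound 1 also sits at a limit, so no step between compound 1 and compound 3 can be read. The compounds shown leave open at what concentration any of them becomes cytotoxic.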